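Trifluoromethyl for isopropoxy: little change in half-life expected

This account rests on a few compounds, and the source may have more. Where it says the series, first, only, none or still open, it means among the compounds named here.

In an in vitro ADME assay on microsomes (Homo sapiens) for metabolic stability (on this read-out higher numbers stand for a longer-lived compound and lower numbers for a shorter-lived compound), compound 1 `CCc1nc(-c2ccc(OC(F)(F)F)cc2OC)c(CC)nc1NC(CC)CC` gives 0.217 h as its half-life. Compound 2 `CCc1nc(-c2ccc(C)cc2OC)c(CC)nc1NC(CC)CC` gives 0.183 h on the same read-out. Compound 3 `CCc1nc(-c2ccc(OC(C)C)cc2OC)c(CC)nc1NC(CC)CC` gives 0.183 h here. Compound 3 is therefore level with compound 2 at the digits shown, and compound 1 lies within the scatter of both.

Compound 4 `CCc1nc(-c2ccc(C(F)(F)F)cc2OC)c(CC)nc1NC(CC)CC` has not yet been measured. It differs from compound 3 by a single change, (trifluoromethyl in place of isopropoxy on an aromatic carbon), which is trifluoromethyl in place of isopropoxy on an aromatic carbon, meta to a methoxy group and para to a large group.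

The three measured steps all concern the group at this same place. They are a 1.2-fold lower number from compound 1 to compound 2 (0.07 log units; within the scatter), a 1.2-fold lower number from compound 1 to compound 3 (0.07 log units; within the scatter) and no change at the digits printed from compound 2 to compound 3 (within the scatter). All three stay within the scatter, across trifluoromethoxy, methyl and isopropoxy. Going by the values given here, no compound with trifluoromethyl has been measured, so this expectation rests on those neighbours alone. The expected step is small, a 1.1-fold higher number from compound 3 to compound 4 (0.04 log units; within the scatter), and is not expected to exceed the scatter in this assay. For compound 4 the estimated half-life is 0.2 h, with an expected range of 0.12 h to 0.33 h in this measurement.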

Compound 4, half-life: 0.183 h
Estimate against measurement, compound 4: 1.1-fold (0.04 log units) above, within the range that was stated.
By their numbers in this assay, from the lowest: compounds 2, 3, 4 and 1 (each within the scatter of the next).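

Trifluoromethyl on this aromatic carbon, para to a large group and meta to a methoxy group, now reads in this assay as no change at the digits printed from compound 3 to compound 4 (within the scatter) and as no change at the digits printed from compound 2 to compound 4 (within the scatter) and as a 1.2-fold lower number from compound 1 to compound 4 (0.07 log units; within the scatter) so every pair among the four compounds lies within the scatter. The change from isopropoxy gives up the hydrogen-bond acceptor of that group, and the change from trifluoromethoxy gives up the linking oxygen, yet neither step leaves the scatter on this read-out. With a fourth group in place, none of trifluoromethoxy, methyl, isopropoxy or trifluoromethyl separates from the others in half-life, so this position has not yet shown a handle on the number in any of the compounds at hand.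

On these data alone, whether an amine, a carboxylic acid or a longer chain on this same carbon would also stay within the scatter remains open, as does the effect of changes elsewhere on the shared core. Nothing at hand explains why the half-life shows no step beyond the scatter at this position.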